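Methyl on the ring carbon: one change, two settings

The source may report more compounds than this note shows. Statements on the series, on what has been measured and on what is new or still open speak of the compounds shown alone.

The series consists of four compounds built on a shared core bearing a phenyl-type group, an indole-type group and a carbonyl-linked six-membered aromatic ring with one nitrogen. Compound 1 is `Cn1cc(C2CC(c3ccccc3)=NN2C(=O)c2cccnc2)c2ccccc21` and compound 2 is `Cc1ccc(C(=O)N2N=C(c3ccccc3)CC2c2cn(C)c3ccccc23)cn1`. In a functional assay on HepG2 cells (Homo sapiens) for inhibition, read by MTT assay, with a stated time of 48 h (a higher number here means a weaker inhibitor of growth, a lower number a stronger inhibitor of growth), compound 1 gives 4630 nM, and compound 2 gives 1220 nM. Going by the values given here, the only change between them is methyl in place of hydrogen on an aromatic carbon, and it produced a 3.8-fold lower number from compound 1 to compound 2 (0.58 log units; beyond the scatter).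

Compound 3 is `COc1cccc(C2=NN(C(=O)c3cccnc3)C(c3cn(C)c4ccc(OC)cc34)C2)c1`; how its core differs from that of compound 1 is not broken down here. In this assay compound 3 gives 910 nM, a number that sits within the usual scatter of the value of compound 2, so no order between those two can be claimed, while it lies beyond the scatter from compound 1.

Compound 4 is `COc1cccc(C2=NN(C(=O)c3ccc(C)nc3)C(c3cn(C)c4ccc(OC)cc34)C2)c1`. Its difference from compound 3 is methyl in place of hydrogen on an aromatic carbon, the same change that was already seen between compound 1 and compound 2, made at the same place. Among the compounds with values here, the step is estimated at a 2.6-fold lower number from compound 3 to compound 4 (0.41 log units; beyond the scatter), a little smaller than the earlier one, because the same change gave a 3.8-fold lower number from compound 1 to compound 2 (0.58 log units; beyond the scatter) in a core that began from a weaker point, and there is only that one pair to rest on. In this assay compound 4 is expected to give about 350 nM, most likely between 150 nM and 900 nM.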

Compound 4, concentration for 50% growth inhibition: 29 nM
Compound 4: middle estimate off by 12-fold (1.08 log units), on the high side, outside the stated range (below it).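

In this assay, the methyl group that turns pyridin-3-yl into 6-methylpyridin-3-yl gave a 31-fold lower number from compound 3 to compound 4 (1.50 log units; beyond the scatter), so the number fell on both cores, but the two steps differ in size: the same change on two cores in this assay, a 3.8-fold lower number (0.58 log units; beyond the scatter) from compound 1 to compound 2 and a 31-fold lower number (1.50 log units; beyond the scatter) from compound 3 to compound 4, 8.3-fold (0.92 log units) apart, beyond the scatter of two such steps

The direction of the change therefore carried from the core of compound 1 to the core of compound 3, while its size did not, and a step read on one of these cores cannot be applied as a fixed amount to the other. Going by these compounds alone, with only two matched pairs, this shows that the size of the step depends on the core, but it does not show which feature of the two cores sets that size, or how the methyl group acts in either setting.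

The compounds shown leave open whether an ethyl group, a longer chain, a chlorine atom or an amine in place of that methyl group would lower the number further, or would raise it. They also leave open whether the larger step would appear on a third core, or whether the step seen on the core of compound 3 is particular to that core.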